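Compound 1 to compound 4: chloro replaced by hydrogen

This account rests on a few compounds, and the source may have more. Where it says the series, first, only, none or still open, it means among the compounds named here.

Compound 1 `O=C1c2ccc(Cl)cc2CN1c1cccnc1` holds the highest of the two numbers recorded in an ADME assay on cells for inhibition of cytochrome P450 11B1, mitochondrial (Homo sapiens), read by HTRF (a lower number here means a stronger inhibitor, a higher number a weaker inhibitor), where compound 1 gives 10700 nM. Compound 2 `CC(=O)N[C@@H]1CCCc2c1cncc2N1CCc2cc(Cl)ccc2C1=O` gives 3920 nM in this assay, a lower number than compound 1, and the gap between the two lies beyond the usual scatter. Compound 3 `O=C(Nc1cccnc1)c1ccc(Cl)cc1F` appears in this assay only as a limit, > 3000 nM, which is the limit of > 3000 nM in this assay, at which 1 of the 3 values shown sits, and not a number.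

Compound 4 `O=C1c2ccccc2CN1c1cccnc1` differs from compound 1 in one place, hydrogen in place of chloro on an aromatic carbon. Going by the values given here, no measured pair of compounds shows this exact change, so the size of the step has to be estimated from compound 1 alone. The step from compound 1 to compound 4 is expected to be a 1.9-fold higher number from compound 1 to compound 4 (0.27 log units; within the scatter), a modest move toward weaker inhibition, though a step within the scatter would not surprise. For compound 4 the estimate in this assay is 20000 nM, with a range from 6000 nM to 60000 nM.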

Compound 4, half-maximal inhibitory concentration: > 3000 nM
Compound 4 was reported as a limit (the forecaster's own chance of this, stated with the estimate: 25%); the middle value is on the limit's open side.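

In this assay, going by these compounds alone, compound 4 is reported as > 3000 nM, a limit and not a number, so no step from compound 1 to compound 4 can be read. The compounds shown leave open whether, and how far, hydrogen in place of chloro on an aromatic carbon shifts the number.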